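The source may report more compounds than this note shows. Statements on the series, on what has been measured and on what is new or still open speak of the compounds shown alone.

Measured so far:
- compound 1, `COc1ccc(CCCN2CCC(COCc3ccccn3)CC2)cc1` — in a functional assay on cells (T-cell line, Homo sapiens) for inhibition (on this read-out higher numbers stand for weaker inhibition and lower numbers for stronger inhibition), compound 1 gives 5900 nM
- compound 2, `Clc1ccccc1CCCN1CCC(COC(c2ccccc2)c2ccccc2)CC1` — in this assay compound 2 gives 800 nM

Within the data shown here, of the two numbers, compound 2 has the lower one, and its gap to compound 1 lies beyond the scatter of repeated measurements; no single-point step connects the two, so only the two values themselves can be compared. Compound 3, `CCCCCCCCCN1CCC(COC(c2ccccc2)c2ccccc2)CC1`, has not yet been measured. It differs from compound 2 as follows: hexyl in place of 2-chlorophenyl on a saturated chain carbon, three bonds along the chain from an amine nitrogen in a ring. Among the measured compounds shown here, with no measured step of this kind to draw on, the direction of the change is uncertain; a small weakening, or no change beyond the scatter, is expected. The step of a 1.9-fold higher number from compound 2 to compound 3 (0.27 log units; within the scatter) is the estimate. For compound 3 the expected value in this assay is 1500 nM, with a plausible range from 400 nM to 6000 nM.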

Compound 3, half-maximal inhibitory concentration: 700 nM
The estimate for compound 3 lay 2.1-fold (0.33 log units) above the measured number; the range from low to high includes it.
By their numbers in this assay, from the lowest: compounds 3 and 2 (each within the scatter of the next); then compound 1.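

In this assay, putting hexyl in place of 2-chlorophenyl on a saturated chain carbon, three bonds along the chain from an amine nitrogen in a ring, gives a 1.1-fold lower number from compound 2 to compound 3 (0.06 log units; within the scatter). This is the only single-point step shown, and it indicates that at this position neither the aromatic ring nor the chlorine of 2-chlorophenyl is needed to keep the read-out within the scatter of compound 2. No measured evidence bears on why the two groups read alike.

On these data alone, whether this tolerance extends beyond hexyl remains open: a shorter chain such as propyl, or a chain ending in an amine or a carboxylic acid, could read differently. As far as these compounds go, it is also open whether the same exchange would give a similar step on the core of compound 1.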